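A few compounds are considered here, and "the series" means these few. Any claim that something is new, unique, unknown or untested is made for them only; others in the source may bear on it.

Compounds measured so far:
compound 1 `CC(C)C(C(N)=O)c1ccc(Cl)cc1` — > 100000 nM
compound 2 `CC(C)[C@H](C(=O)Nc1ccccn1)c1ccc(Cl)cc1` — 1400 nM
compound 3 `CC(C)[C@H](C(=O)Nc1ccc(F)cn1)c1ccc(Cl)cc1` — 1300 nM

Compound 1 is the parent of this small set. In a functional assay on CHO cells for agonist activity at Free fatty acid receptor 2 (Homo sapiens), read by cAMP accumulation (a lower number here means a stronger inhibitor, a higher number a weaker inhibitor), compound 1 gives > 100000 nM, which is a limit of the assay and not a number; it sits at the limit of > 100000 nM in this assay, at which 1 of the 3 values shown sits. Compound 2 carries a substituent on the amide-type nitrogen and gives 1400 nM in this assay. Going by the values given here, compound 3 gives 1300 nM, and the only single-point step measured, a 1.1-fold lower number from compound 2 to compound 3 (0.03 log units; within the scatter), shows that a fluoro on the aromatic carbon of that substituent changes nothing beyond the scatter.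

The unmeasured compound 4 `CC(C)C(C(=O)Nc1cnccn1)c1ccc(Cl)cc1` differs from compound 1 by pyrazin-2-yl in place of hydrogen on an amide-type nitrogen. Among the compounds with values here, no measured step covers this exact change; what the values show is that compound 1 sits at a limit while compounds 2 and 3, each bearing a ring on that nitrogen, give numbers. For compound 4 the account therefore expects a step in this assay of an at least 40-fold lower number from compound 1 to compound 4 (1.60 log units; beyond the scatter), downward from the limit of compound 1 into the measurable range. The estimate for compound 4 in this assay is 2500 nM, expected to lie between 700 nM and 12000 nM.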

Compound 4, half-maximal inhibitory concentration: 5700 nM
The estimate for compound 4 lay 2.3-fold (0.36 log units) below the measured number; the range from low to high includes it.
By their numbers in this assay, from the lowest: compounds 3 and 2 (each within the scatter of the next); then compound 4. At a limit, above all of these: compound 1.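

In this assay, pyrazin-2-yl in place of hydrogen on an amide-type nitrogen gives an at least 17-fold lower number from compound 1 to compound 4 (1.24 log units; beyond the scatter), the only step shown that directly measures a change at this position from the parent. Going by these compounds alone, earlier, the one measured step concerned only a fluoro on a ring already on that nitrogen, so the effect of replacing the amide hydrogen itself had not been measured directly. The value of compound 1 is a limit of the assay and not a number, so the true size of this step stays unknown: the limit of > 100000 nM in this assay, at which 1 of the 4 values shown sits.

The compounds shown leave open whether an open chain on that nitrogen, such as a propyl group, would also bring the value into the measurable range. They also leave open how a carboxylic acid or an amine on the pyrazin-2-yl ring would act.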